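Phenoxy to Methoxy on the Pyridine of Compound 3

This account rests on a few compounds, and the source may have more. Where it says the series, first, only, none or still open, it means among the compounds named here.

Of the compounds shown here, three on a shared bicyclic amine core have been measured in an in vitro functional assay on SH-EP1 cells for agonist activity at Neuronal acetylcholine receptor; alpha4/beta2 (Homo sapiens), read by FLIPR and calcium flux; on this read-out lower numbers stand for an effect already at smaller amounts and higher numbers for an effect only at larger amounts of compound. Compound 1 `Clc1ccncc1C1=CC2CNCC(C1)C2` gives only a limit, > 10000 nM, and no number. Compound 2 `COc1ccc(C2=CC3CC(C2)CN(C)C3)cn1` likewise gives only the limit > 10000 nM in this assay. Going by the values given here, compound 3 `C1=C(c2cncc(Oc3ccccc3)c2)CC2CNCC1C2`, which carries a phenoxy group on its pyridine, is the one compound with a measured number, 654 nM in this assay, and so it stands alone among the values shown; the other two sit at the limit of > 10000 nM in this assay, at which 2 of the 3 values shown sit.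

Compound 4 `COc1cncc(C2=CC3CNCC(C2)C3)c1` differs from compound 3 in one place: methyl in place of phenyl on an oxygen on an aromatic ring. Among the compounds with values here, no pair of measured compounds differing in a single place is available, so the size of this step cannot be read off directly. Compound 2 also bears a methoxy group on its pyridine and sits at the limit, but it differs from compound 4 in more than one place, so only its own value can be cited.

The step from compound 3 to compound 4 is expected to cost potency by a 6.1-fold higher number from compound 3 to compound 4 (0.79 log units; beyond the scatter), beyond the usual scatter. Compound 4 is therefore estimated at 4000 nM in this assay, with a range from 800 nM to 20000 nM, and a real chance that only a limit is reported.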

Compound 4, half-maximal effective concentration: 53 nM
For compound 4 the middle estimate is 75-fold (1.88 log units) above the measured one; the measured number lies below the stated range.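

At this position, on an oxygen on an aromatic ring, the phenoxy to methoxy change moves the read-out in this assay by a 12-fold lower number from compound 3 to compound 4 (1.09 log units; beyond the scatter), so the large phenyl group is not needed for agonist activity in this series, and the methyl group that replaces it gives the lower number of the pair. The earlier compounds shown here could not show this, since they offered a single number and no pair differing in one place, which left both the direction and the size of any change at this oxygen unknown. The picture now has two numbers, while the remaining values are limits and not numbers: the limit of > 10000 nM in this assay, at which 2 of the 4 values shown sit.

As far as these compounds go, only methyl and phenyl have been seen on this oxygen, so it remains open whether the trend follows group size, and where an ethyl, a benzyl or a free hydroxyl group would fall, or an amine in place of the oxygen. Going by these compounds alone, compound 1 and compound 2 differ from compound 4 in more than one place, so no step to either can be read, and what the chloro group or the methyl on the core nitrogen contributes remains unresolved.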